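Phenylpropyl in place of a short alkene on the ester

This account rests on a few compounds, and the source may have more. Where it says the series, first, only, none or still open, it means among the compounds named here.

Four esters share one core. In a functional assay on SW1573 cells (Homo sapiens) for inhibition, read by sulforhodamine B assay, with a stated time of 48 h (a higher number here means a weaker inhibitor of growth, a lower number a stronger inhibitor of growth), compound 1 `O=C(CCCCC1CCCCC1)OCC1COCCOCCOCCOCCOCCO1` gives 51000 nM, and compound 3 `O=C(CCCCCCCCCCOc1ccccc1)OCC1COCCOCCOCCOCCOCCO1` gives 24000 nM. Compound 2 `CC/C=C/CC(=O)OCC1COCCOCCOCCOCCOCCO1` gives only a limit, > 100000 nM, which is not a measured number. Compound 2 therefore stands at the limit of > 100000 nM in this assay, at which 1 of the 3 values shown sits. Among the measured compounds shown here, the one measured step, an at least 1.9-fold higher number from compound 1 to compound 2 (0.29 log units; that floor lies within the scatter), describes the exchange of 3-cyclohexylpropyl for but-1-en-1-yl. Compound 4 `O=C(CCCCc1ccccc1)OCC1COCCOCCOCCOCCOCCO1` differs from compound 2 by 3-phenylpropyl in place of but-1-en-1-yl on a saturated chain carbon bound to a carbonyl carbon. Because compound 1, with its 3-cyclohexylpropyl chain, gives 51000 nM, the return to a longer chain is expected to lower the number, as the estimated step of an at least 2.0-fold lower number from compound 2 to compound 4 (0.30 log units; that floor lies within the scatter) shows. Compound 4 is expected at 50000 nM, within a range from 20000 nM to 120000 nM.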

Compound 4, concentration for 50% growth inhibition: > 100000 nM
Compound 4 gave a limit, no number; the forecaster's own chance of this, stated with the estimate: 25%; middle value at least 2.0-fold (0.30 log units) from the limit.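

In this assay compound 4 gives only a limit, not a number. So at this position, a chain ending in a phenyl ring does not yield a measured value, although compound 1, with its cyclohexyl end, does: phenyl in place of cyclohexyl gives an at least 1.9-fold higher number from compound 1 to compound 4 (0.29 log units; that floor lies within the scatter). Compound 2 and compound 4 are both limits, so the step between them cannot be read, and the shown values now include two such results: the limit of > 100000 nM in this assay, at which 2 of the 4 values shown sit.

Still open, on these data alone, is how far this limit lies from a real value. An amine or a carboxylic acid on the end of the chain also remains untested among the compounds shown.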